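The compounds below may be only part of what the source reports. "The series", "measured", "known", "first", "only" and "open" are said of these compounds alone.

The series shares one core, carried by compound 1 `NC(=O)c1c(NC(=O)c2ccccc2Cl)sc2c1CCN(Cc1ccccc1Cl)C2`, compound 2 `NC(=O)c1c(NC(=O)c2ccccc2Cl)sc2c1CCN(C(=S)Nc1ccccc1I)C2` and compound 3 `Cc1ccccc1NC(=S)N1CCc2c(sc(NC(=O)c3ccccc3Cl)c2C(N)=O)C1`. In a functional assay on HeLa cells (Homo sapiens) for antiproliferative activity, with a stated time of 24 h (a higher number here means a weaker inhibitor, a lower number a stronger inhibitor), compound 1 gives 27500 nM. In this assay compound 2 gives 29000 nM. Compound 3 reaches only the limit of this assay, where compound 3 gives > 50000 nM, a limit and not a number (the limit of > 50000 nM in this assay, at which 1 of the 3 values shown sits). The measured steps are a 1.1-fold higher number from compound 1 to compound 2 (0.02 log units; within the scatter), an at least 1.8-fold higher number from compound 1 to compound 3 (0.25 log units; that floor lies within the scatter) and an at least 1.7-fold higher number from compound 2 to compound 3 (0.23 log units; that floor lies within the scatter); none leaves the scatter, so compound 3 stands with the other two among the numbers shown, its own value known only as a limit.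

Compound 4 `NC(=O)c1c(NC(=O)c2ccccc2Cl)sc2c1CCN(C(=S)Nc1cccnc1)C2` differs from compound 3 by pyridin-3-yl in place of 2-methylphenyl on an amide-type nitrogen. The step bearing most directly on this exchange is an at least 1.7-fold higher number from compound 2 to compound 3 (0.23 log units; that floor lies within the scatter), a change within the same group that stayed within the scatter; a 1.1-fold higher number from compound 1 to compound 2 (0.02 log units; within the scatter) and an at least 1.8-fold higher number from compound 1 to compound 3 (0.25 log units; that floor lies within the scatter) likewise replaced the whole group on the ring amine nitrogen without a step beyond the scatter. No step beyond the scatter is therefore expected in this assay, in either direction. For compound 4 the estimate is 45000 nM, between 20000 nM and 100000 nM. The step this expectation means is an at least 1.1-fold lower number from compound 3 to compound 4 (0.04 log units; that floor lies within the scatter).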

Compound 4, half-maximal inhibitory concentration: > 50000 nM
Compound 4 gave a limit, no number (the forecaster's own chance of this, stated with the estimate: 50%); at least 1.1-fold (0.04 log units) between middle value and limit.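

In this assay compound 4 gives > 50000 nM, a limit and not a number. The steps to it are an at least 1.7-fold higher number from compound 2 to compound 4 (0.23 log units; that floor lies within the scatter) and an at least 1.8-fold higher number from compound 1 to compound 4 (0.25 log units; that floor lies within the scatter), so a ring with a hetero atom on this amide-type nitrogen shows no step beyond the scatter from either compound. The step from compound 3 to compound 4 cannot be read, and 2-methylphenyl and pyridin-3-yl on this nitrogen both end at the same limit: the limit of > 50000 nM in this assay, at which 2 of the 4 values shown sit.

From the compounds shown here alone, the true values of compound 3 and compound 4 stay open, and with them any real difference between 2-methylphenyl and pyridin-3-yl. Also open, going by these compounds, is whether a group without an aromatic ring on this nitrogen, such as a short alkyl chain or a carboxylic acid on such a chain, would give a number under the limit.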